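This account rests on a few compounds, and the source may have more. Where it says the series, first, only, none or still open, it means among the compounds named here.

Of the compounds shown here, two from this series have been tested in a functional assay on KB cells (Homo sapiens) for inhibition, read by MTT assay, with a stated time of 24 h, tested at 5 uM; a higher number here means more inhibition of growth at the concentration tested, a lower number less inhibition of growth. Compound 1, with the structure `CS(=O)(=O)c1ccc(-c2cnc3[nH]cc(-c4nnc(-c5ccc(F)cc5)o4)c(=O)c3c2)cc1`, gives 2.55%. Compound 2, with the structure `N#Cc1ccc(-c2cnc3[nH]cc(-c4nnc(-c5ccc(Cl)cc5)o4)c(=O)c3c2)cc1`, gives 7.35%. The two numbers lie within the usual scatter of repeated measurements of each other, so compound 1 cannot be told apart from compound 2 on this basis; both compounds show only weak inhibition of cell growth at the tested concentration.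

Compound 3, with the structure `Cc1cccc(-c2nnc(-c3c[nH]c4ncc(-c5ccc(S(C)(=O)=O)cc5)cc4c3=O)o2)c1`, has not yet been measured in this assay. It differs from compound 1 in one place: 3-methylphenyl in place of 4-fluorophenyl on an aromatic carbon. In words, a 3-methylphenyl replaces a 4-fluorophenyl on an aromatic carbon of the shared core.

Going by the values given here, no pair of measured compounds differing in a single place is available to show how such a swap affects the read-out, so there is no measured step to lean on. Since compound 1 gives 2.55% and compound 2 gives 7.35%, both showing only weak inhibition, the step of a number 2.5 percentage points higher from compound 1 to compound 3 (within the scatter) is expected to stay within the scatter and carry no clear direction. Compound 3 is expected to give about 5%, with a plausible range from -5% to 18%.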

Compound 3, percent growth inhibition at one concentration: 3.7%
Estimate against measurement, compound 3: 1.3 percentage points above; the measured number falls inside the stated range.
By their numbers in this assay, from the lowest: compounds 1, 3 and 2 (each within the scatter of the next).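

In this assay, going by these compounds alone, this is the first measured swap at a single place: on an aromatic carbon of the five-membered aromatic ring with 2 nitrogen and 1 oxygen, 3-methylphenyl replaces 4-fluorophenyl, giving a number 1.2 percentage points higher from compound 1 to compound 3 (within the scatter). At this position, then, exchanging one phenyl group for another, with a methyl in place of the fluorine and sitting elsewhere on the ring, leaves no effect that can be separated from ordinary assay variation, and growth inhibition stays weak at the tested concentration. No measurement of any other property is available to account for this result.

One swap between two weakly inhibiting compounds cannot show whether this position can influence growth inhibition at all, or whether any effect would appear only with a much larger change. A phenyl ring carrying an amine or a carboxylic acid, or a longer alkyl chain in place of the ring, could show whether this read-out responds to a group of a different kind at this position.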